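This account rests on a few compounds, and the source may have more. Where it says the series, first, only, none or still open, it means among the compounds named here.

Measured so far in a functional assay on SSMC-7721 cells (Homo sapiens) for antiproliferative activity, read by CCK-8 assay, with a stated time of 48 h; on this read-out higher numbers stand for weaker inhibition and lower numbers for stronger inhibition:
compound 1 `O=c1c2ccccc2[se]n1-c1nnc(-c2ccc(Br)cc2)s1` gives 68200 nM
compound 2 `O=c1c2ccccc2[se]n1-c1nnc(-c2cccc([N+](=O)[O-])c2)s1` gives 27300 nM

Compound 2 holds the lowest of the two numbers; compound 1 sits at a higher number, a gap beyond the usual scatter. Compound 3 `O=c1c2ccccc2[se]n1-c1nnc(-c2cc([N+](=O)[O-])cc([N+](=O)[O-])c2)s1` differs from compound 2 by one change: nitro in place of hydrogen on an aromatic carbon. Going by the values given here, no measured pair shows this step, so its size is open. A second nitro group is expected to move the value little beyond the scatter, if anything slightly lower; the expected step from compound 2 to compound 3 is a 1.4-fold lower number from compound 2 to compound 3 (0.14 log units; within the scatter). For compound 3 the estimate in this assay is 20000 nM, with a range from 6000 nM to 60000 nM.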

Compound 3, half-maximal inhibitory concentration: 21600 nM
Compound 3: the middle estimate sits 1.1-fold (0.03 log units) below what was measured; the range from low to high includes it.
By their numbers in this assay, from the lowest: compounds 3 and 2 (each within the scatter of the next); then compound 1.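

In this assay the aromatic carbon meta to a large group and meta to a nitro group accepts a second nitro group, and the step reads a 1.3-fold lower number from compound 2 to compound 3 (0.10 log units; within the scatter). Compound 2 and compound 3 therefore stay within the scatter of each other, so the three extra heavy atoms of this nitro group leave the read-out unresolved from that of compound 2. Nothing at hand accounts for this result.

Only nitro has been seen at this position, so an amine, a carboxylic acid or a methoxy group there remains an open question. From the compounds shown here alone, whether any of these would separate from compound 2 beyond the scatter also remains open.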